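This account rests on a few compounds, and the source may have more. Where it says the series, first, only, none or still open, it means among the compounds named here.

Measured compounds in a functional assay on A549 cells (Homo sapiens) for cytotoxicity, read by MTT assay, with a stated time of 72 h; a higher number here means a weaker inhibitor, a lower number a stronger inhibitor:

compound 1 `CN(C)CCn1cnnc1-c1cc(Oc2ccc(NC(=O)N/N=C/c3cccc(Br)c3)cc2F)ccn1` gives 970 nM
compound 2 `CN(C)CCn1cnnc1-c1cc(Oc2ccc(NC(=O)N/N=C/c3ccc(O)c(F)c3)cc2F)ccn1` gives 13400 nM
compound 3 `CN(C)CCn1cnnc1-c1cc(Oc2ccc(NC(=O)N/N=C/c3ccc(O)cc3O)cc2F)ccn1` gives 12700 nM

Compound 3 sits near the top of these three numbers: its value and that of compound 2 lie within the scatter of each other, while compound 1 is far off, with a 13-fold higher number from compound 1 to compound 3 (1.12 log units; beyond the scatter).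

Compound 4 `Cc1cc(/C=N/NC(=O)Nc2ccc(Oc3ccnc(-c4nncn4CCN(C)C)c3)c(F)c2)cc(C)c1O` has not yet been measured. It differs from compound 3 in one place: 4-hydroxy-3,5-dimethylphenyl in place of 2,4-dihydroxyphenyl on a carbon with a double bond to nitrogen. The hydroxyl that points away from the attachment stays, and two methyl groups join it on the ring.

Two of the measured steps bear on this. Going from the bromophenyl to a hydroxyphenyl gave a 14-fold higher number from compound 1 to compound 2 (1.14 log units; beyond the scatter) and a 13-fold higher number from compound 1 to compound 3 (1.12 log units; beyond the scatter). Between the two hydroxyphenyl compounds themselves the step was a 1.1-fold lower number from compound 2 to compound 3 (0.02 log units; within the scatter), so the exact decoration of a hydroxyphenyl changed little. For the measured compounds named here, no measured pair shows what methyl groups do here. The expectation is therefore a value close to compounds 2 and 3, with a 1.3-fold lower number from compound 3 to compound 4 (0.10 log units; within the scatter) estimated to stay within the scatter.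

Compound 4 is expected to give about 10000 nM, with a plausible range from 3500 nM to 30000 nM.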

Compound 4, half-maximal inhibitory concentration: 1640 nM
Compound 4: middle estimate off by 6.1-fold (0.79 log units), on the high side, and the stated range ends above it.
By their numbers in this assay, from the lowest: compounds 1 and 4 (each within the scatter of the next); then compounds 3 and 2 (each within the scatter of the next).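

In this assay, the decoration of a hydroxyphenyl ring turns out to matter after all: moving to 4-hydroxy-3,5-dimethylphenyl gives a 7.7-fold lower number from compound 3 to compound 4 (0.89 log units; beyond the scatter) and an 8.2-fold lower number from compound 2 to compound 4 (0.91 log units; beyond the scatter), so a hydroxyl on this ring does not by itself bring the high numbers of compounds 2 and 3. For the compounds shown here, the 3-bromophenyl group is also not the only group at this position that gives a low number, since replacing it with the methylated hydroxyphenyl gives a 1.7-fold higher number from compound 1 to compound 4 (0.23 log units; within the scatter), a change within the scatter. No measurement at hand explains why the two methyl groups go with this lower number.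

The compounds shown cannot separate the contribution of the two methyl groups from that of the groups they replace, since the second hydroxyl leaves in one step and the fluorine in the other. Going by these compounds, it also remains open whether a ring with a single methyl group would behave the same way, and whether the remaining hydroxyl could be exchanged for a methoxy group or an amine without raising the number.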